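Aryl in place of alkyl at the assay limit

A few compounds are considered here, and "the series" means these few. Any claim that something is new, unique, unknown or untested is made for them only; others in the source may bear on it.

Compound 1, `CCc1cc(-c2nn(C(C)C)c3ncnc(N)c23)no1`: > 10000 nM
Compound 2, `CC(C)n1nc(/C=N/OCc2ccccc2)c2c(N)ncnc21`: > 10000 nM
Compound 3, `CC(C)n1nc(/C=N/O)c2c(N)ncnc21`: > 10000 nM

In an ADME assay on BaF3 cells (Mus musculus) for cytotoxicity, read by MTT assay, with a stated time of 48 h (a lower number here means a stronger inhibitor of growth, a higher number a weaker inhibitor of growth), compound 1 gives > 10000 nM, which is a limit of the assay and not a number. Compound 2 also sits at a limit, giving > 10000 nM. Compound 3 likewise gives > 10000 nM, a limit. Going by the values given here, every value shown therefore rests at the limit of > 10000 nM in this assay, at which 3 of the 3 values shown sit, and the one step between measured neighbours, a step that the two limits leave unreadable from compound 2 to compound 3, carries no readable size. Compound 1 stands where all three stand: at the limit, with no number to place it above or below its companions.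

Compound 4, `CC(C)n1nc(-c2cc(-c3ccc(F)cc3)on2)c2c(N)ncnc21`, differs from compound 1 by 4-fluorophenyl in place of ethyl on an aromatic carbon. No measured step touches this position, and the only step shown is unreadable, so nothing in the data sets a size or a direction for the change. The step of a number no higher from compound 1 to compound 4 (the limit leaves the size open) is therefore expected to be small or to remain hidden behind the limit. Compound 4 is estimated at 10000 nM, with a range from 2000 nM to 30000 nM.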

Compound 4, concentration for 50% growth inhibition: > 10000 nM
Compound 4: a limit, no number; the forecaster's own chance of this, stated with the estimate: 60%; the middle value lies on the limit itself.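

In this assay compound 4 gives > 10000 nM, a limit and not a number. The step between compound 1 and compound 4 therefore cannot be read: the limit of > 10000 nM in this assay, at which 4 of the 4 values shown sit. The compounds shown leave open how strongly any of them inhibits growth, and whether any change on the shared core alters that.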